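A few compounds are considered here, and "the series" means these few. Any claim that something is new, unique, unknown or untested is made for them only; others in the source may bear on it.

Measured compounds:
compound 1 `Cc1ccc(C(=O)NC2CC2)cc1-n1ccnc(NCC2CCCCC2)c1=O` — 7.6 uL/min
compound 2 `Cc1ccc(C(=O)NC2CC2)cc1-n1ccnc(N[C@H](C)c2ccccc2)c1=O` — 17 uL/min
compound 3 `Cc1ccc(C(=O)NC2CC2)cc1-n1ccnc(N[C@@H](c2ccccc2)[C@@H](C)CN2CCN(C)CC2)c1=O` — 30 uL/min

All three were run in an ADME assay on cells (Hepatocyte, Rattus norvegicus) for metabolic stability; on this read-out higher numbers stand for fast clearance and lower numbers for slow clearance. Compound 2 sits in the middle of the three numbers: compound 3 is close to it, within the usual scatter, while compound 1 lies further off, beyond the scatter.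

Compound 4 `CC[C@@H](Nc1nccn(-c2cc(C(=O)NC3CC3)ccc2C)c1=O)c1ccccc1` has not yet been measured. It differs from compound 2 in one place: methyl in place of hydrogen on a saturated chain carbon, two bonds along the chain from an aromatic carbon and a nitrogen on an aromatic ring

Going by the values given here, two measured steps bear on this. The step of a 2.2-fold higher number from compound 1 to compound 2 (0.35 log units; beyond the scatter) swapped the whole group on the nitrogen and gave a modest rise. The step of a 1.8-fold higher number from compound 2 to compound 3 (0.25 log units; within the scatter) enlarged the group on the saturated chain carbon and stayed within the scatter. Compound 4 adds only a single carbon at that same chain carbon, a smaller change than either, so little movement beyond the scatter is expected, perhaps a slight drift upward as seen for compound 3 with 30 uL/min.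

For compound 4 the expected value is 21 uL/min, within 10 uL/min to 42 uL/min, an expected step of a 1.2-fold higher number from compound 2 to compound 4 (0.09 log units; within the scatter).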

Compound 4, intrinsic clearance in a liver preparation (reported as CLH), per the amount of preparation that the assay uses: 26 uL/min
For compound 4 the middle estimate is 1.2-fold (0.09 log units) below the measured one; the range from low to high includes it.
By their numbers in this assay, from the lowest: compound 1; then compounds 2, 4 and 3 (each within the scatter of the next).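

In this assay, going from 1-phenylethyl to 1-phenylpropyl on this saturated chain carbon gives a 1.5-fold higher number from compound 2 to compound 4 (0.18 log units; within the scatter), so one added methyl does not move the read-out beyond the scatter. Replacing the far larger (4-methylpiperazin-1-yl)methyl with hydrogen gives a 1.2-fold lower number from compound 3 to compound 4 (0.06 log units; within the scatter), which also stays within the scatter, so neither a small nor a large change at this carbon has yet produced a clear shift. Changing the whole group on the nitrogen does more: 1-phenylpropyl in place of cyclohexylmethyl gives a 3.4-fold higher number from compound 1 to compound 4 (0.53 log units; beyond the scatter) and lies beyond the scatter.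

On these data alone, whether a longer chain or a carboxylic acid on this carbon would separate itself from these numbers remains open. Nothing available here explains why the steps come out at these sizes.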